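Swapping the aryl group on the ring-bound benzyl arm

This account rests on a few compounds, and the source may have more. Where it says the series, first, only, none or still open, it means among the compounds named here.

Measured compounds:
compound 1 `CC1(C)c2[nH]nc(NC(=O)c3ccccc3)c2CN1Cc1cccc(Br)c1` — 940 nM
compound 2 `CC1(C)c2[nH]nc(NC(=O)c3ccccc3)c2CN1Cc1ccc(F)cc1F` — 2320 nM

Going by the values given here, in an assay on Sf21 cells for inhibition of high affinity nerve growth factor receptor (Homo sapiens), read by HTRF, with a stated time of 30 min, in the presence of a further agent that is not named here (a lower number here means a stronger inhibitor, a higher number a weaker inhibitor), compound 2 gives the higher of the two numbers recorded so far, and the step of a 2.5-fold higher number from compound 1 to compound 2 (0.39 log units; beyond the scatter) places it beyond the scatter from its only neighbour. Compound 3 `Cc1ccc(F)c(CN2Cc3c(NC(=O)c4ccccc4)n[nH]c3C2(C)C)c1` has not yet been tested. It differs from compound 2 in one place: 2-fluoro-5-methylphenyl in place of 2,4-difluorophenyl on a saturated chain carbon bound to an amine nitrogen in a ring. Among the compounds with values here, the single measured step, from compound 1 to compound 2, exchanged one substituted aryl group for another on the same carbon and shifted the number by a modest amount; no measured step covers the fluorine-to-methyl exchange at hand. A change of similar modest size, in either direction, seems the most likely outcome for compound 3, so a move from compound 2 to compound 3 of a 1.5-fold lower number from compound 2 to compound 3 (0.16 log units; within the scatter) is expected. Compound 3 is therefore estimated at 1600 nM in this assay, with a range from 600 nM to 4500 nM.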

Compound 3, half-maximal inhibitory concentration: 880 nM
Compound 3: middle estimate off by 1.8-fold (0.26 log units), on the high side; the measured number falls inside the stated range.
By their numbers in this assay, from the lowest: compounds 3 and 1 (each within the scatter of the next); then compound 2.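

In this assay, exchanging 2,4-difluorophenyl for 2-fluoro-5-methylphenyl gives a 2.6-fold lower number from compound 2 to compound 3 (0.42 log units; beyond the scatter), so this position responds even when the group keeps its count of 8 heavy atoms and only its substituents change. The second step, a 1.1-fold lower number from compound 1 to compound 3 (0.03 log units; within the scatter), puts 2-fluoro-5-methylphenyl level with 3-bromophenyl, which leaves compound 2 as the weakest of the three, since its steps to both others lie beyond the scatter. Nothing measured here gives a reason for these differences.

The compounds shown do not separate the effect of adding the methyl group from that of losing one fluorine, since both changes arrive together. Also open, as far as these compounds go, is how this arm would read with a methoxy group or an amine on the phenyl ring, or with a pyridine ring in its place.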